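A few compounds are considered here, and "the series" means these few. Any claim that something is new, unique, unknown or untested is made for them only; others in the source may bear on it.

Of the compounds shown here, three sharing a core have been tested in a functional assay on A-431 cells (Homo sapiens) for inhibition, with a stated time of 72 h; a lower number here means a stronger inhibitor, a higher number a weaker inhibitor. Compound 1 (`CCN(CC)Cc1cc(Cl)c2cccnc2c1O`) gives 9330 nM and compound 3 (`CC1CCN(Cc2cc(Cl)c3cccnc3c2O)CC1`) gives 8710 nM, two values within the scatter of each other. Compound 2 (`CCOCc1cc(CN2CCCCC2)c(O)c2ncccc12`) gives 23400 nM, a number beyond the scatter on the weaker side of compound 3. Compound 3 therefore shares the stronger end of this small set with compound 1.

The next structure is compound 4 (`CCOCc1cc(CN2CCC(C)CC2)c(O)c2ncccc12`). The change from compound 3 is ethoxymethyl in place of chloro on an aromatic carbon, para to a hydroxy group. For the measured compounds named here, no two tested compounds differ in one place, so the data hold no direct measure of this swap. Going by the values given here, the nearest guide is compound 2 at 23400 nM, the only tested compound that carries ethoxymethyl, and its number lies above those of the two chloro compounds. On that basis a loss of inhibition in this assay is expected, not a gain. The expected change is a 2.4-fold higher number from compound 3 to compound 4 (0.38 log units; beyond the scatter), a moderate step that would probably lie beyond the scatter. For compound 4 the estimated value is 21000 nM, with an expected range from 10000 nM to 42000 nM.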

Compound 4, half-maximal inhibitory concentration: 11000 nM
Estimate against measurement, compound 4: 1.9-fold (0.28 log units) above; measured number inside the range.
By their numbers in this assay, from the lowest: compounds 3, 1 and 4 (each within the scatter of the next); then compound 2.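

In this assay, ethoxymethyl in place of chloro on this aromatic carbon, para to a hydroxy group, gives a 1.3-fold higher number from compound 3 to compound 4 (0.10 log units; within the scatter) and so leaves no readable change, which shows that this position accepts the larger chain with the methyl-bearing saturated ring in place. For the compounds shown here, the weak number of compound 2 therefore cannot be read as a cost of ethoxymethyl alone: methyl in place of hydrogen on a saturated ring carbon gives a 2.1-fold lower number from compound 2 to compound 4 (0.33 log units; beyond the scatter) with ethoxymethyl held constant, the only step in this set that lies beyond the scatter. No measurement on hand accounts for either step.

The compounds shown do not tell whether the methyl step would appear as well with chloro at the aromatic carbon, since no chloro compound pairs with compound 2 in that way. As far as these compounds go, how plain hydrogen, a methoxymethyl group, an amine or a carboxylic acid at this same aromatic carbon would read remains open, as does any longer chain there.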